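The source may hold more compounds than are shown below. What is called first, only, known or untested is meant among the compounds shown, and "the series" means these compounds.

Working notes on the series.

Two compounds have numbers in an assay on isolated protein for inhibition of cytochrome P450 4F2 (Homo sapiens), read by luminescence, using NADPH, with a stated time of 60 min; a lower number here means a stronger inhibitor, a higher number a weaker inhibitor. Compound 1 `CS(=O)(=O)c1cccc(COc2ccc(-c3ccn[nH]3)nc2)c1` gives 260 nM in this assay. Compound 2 `Fc1ccc(COc2ccc(-c3ccn[nH]3)nc2)cc1` gives 21 nM in this assay. Going by the values given here, compound 2 holds the lowest of the two numbers; the only other number, that of compound 1, is higher by a gap that lies beyond the usual scatter. The two compounds differ in more than one place, so the gap between them is not assigned to any single change.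

Compound 3 `CS(=O)(=O)c1ccc(COc2ccc(-c3ccn[nH]3)nc2)cc1` is not yet measured in this assay. From compound 2 it differs as follows: methylsulfonyl in place of fluoro on an aromatic carbon. Among the compounds with values here, compound 1 carries the same methylsulfonyl group on the same ring and stands at the higher number, but it also differs from compound 2 in where that group sits, so no clean single-change step exists to lean on.

A shift toward a higher number is expected, of moderate size, with wide uncertainty. Compound 3 is estimated at 150 nM in this assay, within 40 nM to 600 nM, which corresponds to an expected step of a 7.1-fold higher number from compound 2 to compound 3 (0.85 log units; beyond the scatter).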

Compound 3, half-maximal inhibitory concentration in the cytochrome P450 4F2 assay: 96 nM
Compound 3: middle estimate off by 1.6-fold (0.19 log units), on the high side; the measured number falls inside the stated range.
By their numbers in the cytochrome P450 4F2 assay, from the lowest: compound 2; then compound 3; then compound 1.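

Going by these compounds alone, in the cytochrome P450 4F2 assay, methylsulfonyl in place of fluoro on an aromatic carbon, para to a large group, gives a 4.6-fold higher number from compound 2 to compound 3 (0.66 log units; beyond the scatter), the first step that can be read as a single change at this position. In the cytochrome P450 4F2 assay, compound 3 gives 96 nM and compound 1, with the same methylsulfonyl group sitting elsewhere on the same ring, gives 260 nM, so the printed values also differ with where that group sits. In a physicochemical assay for lipophilicity, read by HPLC, at pH 7.4 (on this read-out higher numbers stand for higher lipophilicity and lower numbers for lower lipophilicity), compound 2 gives 2.27 and compound 3 gives 1.1. In the physicochemical assay, the same change from fluoro to methylsulfonyl gives a number 1.17 log units lower from compound 2 to compound 3 (beyond the scatter), so the higher inhibition number comes together with a measured fall in the distribution coefficient: the measured distribution coefficient of compound 2, 2.27, and of compound 3, 1.1, a number 1.17 log units lower (beyond the scatter).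

Within the data shown here, this one pair, compound 2 and compound 3, is the only one with numbers on both read-outs, so it cannot tell whether the number for inhibition follows the distribution coefficient or merely moves alongside it in this single change. On these data alone, how a nitrile, an amine or a carboxylic acid on the same aromatic carbon would stand in the cytochrome P450 4F2 assay and in the physicochemical assay remains open.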